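Shifting the group on the amine nitrogen of compound 3

The source may hold more compounds than are shown below. What is called first, only, known or untested is meant among the compounds shown, and "the series" means these compounds.

Measured so far:
compound 1, `CCOC(=O)C1=C(N/C=N/c2ncc(-c3ccccc3)s2)Nc2[nH]nc(C)c2C1c1ccc(N(C)C)cc1`, 9790 nM
compound 2, `CCOC(=O)C1=C(N/N=C(\C#N)C(N)=O)Nc2[nH]nc(C)c2C1c1ccc(N(C)C)cc1`, 48400 nM
compound 3, `CCOC(=O)C1=C(N/C=N/c2ccc([N+](=O)[O-])cc2)Nc2[nH]nc(C)c2C1c1ccc(N(C)C)cc1`, 50900 nM

In a functional assay on HepG2 cells (Homo sapiens) for inhibition, read by MTT assay, with a stated time of 48 h (on this read-out lower numbers stand for stronger inhibition and higher numbers for weaker inhibition), compound 3 gives the highest of the three numbers; against compound 2 the gap is within the scatter, while a 5.2-fold higher number from compound 1 to compound 3 (0.72 log units; beyond the scatter) is beyond it. Compound 4, `CCOC(=O)C1=C(N/N=C(/C(=O)Br)c2ccc(Br)cc2)Nc2[nH]nc(C)c2C1c1ccc(N(C)C)cc1`, differs from compound 3 by a group of 12 heavy atoms (8 carbon, 1 nitrogen, 1 oxygen, 2 bromine; one six-membered aromatic ring of carbon only) in place of a group of 11 heavy atoms (7 carbon, 2 nitrogen, 2 oxygen; one six-membered aromatic ring of carbon only), on an amine nitrogen. Two measured steps change the same position: a 1.1-fold higher number from compound 2 to compound 3 (0.02 log units; within the scatter) stayed within the scatter, and a 5.2-fold higher number from compound 1 to compound 3 (0.72 log units; beyond the scatter) was modest. So swaps at this position have moved the number at most modestly, and no measured pair tells which way the entering group will go. A small shift toward a lower number is expected, a 1.7-fold lower number from compound 3 to compound 4 (0.23 log units; within the scatter), giving an estimated 30000 nM for compound 4, with a range from 8000 nM to 100000 nM.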

Compound 4, half-maximal inhibitory concentration: 65000 nM
The estimate for compound 4 lay 2.2-fold (0.34 log units) below the measured number; the measured number falls inside the stated range.
By their numbers in this assay, from the lowest: compound 1; then compounds 2, 3 and 4 (each within the scatter of the next).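

Both new steps, a 1.3-fold higher number from compound 3 to compound 4 (0.11 log units; within the scatter) and a 1.3-fold higher number from compound 2 to compound 4 (0.13 log units; within the scatter), stay within the scatter, so the group with two bromine atoms cannot be told apart from the two groups it is compared with on this amine nitrogen. Among the compounds shown, only compound 1, at 9790 nM, stands apart from this level. Nothing measured here bears on why this swap left the number level.

Going by these compounds, whether compound 1 owes its lower number to the thiazole or to the phenyl stays open. A plain 1,3-thiazol-2-yl group or a plain phenyl group in the same place would separate the two.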